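A Thiocarbonyl Substituent Swap in a Cytotoxicity Series

A few compounds are considered here, and "the series" means these few. Any claim that something is new, unique, unknown or untested is made for them only; others in the source may bear on it.

Compound 1, `N/C(=N\NC(=S)N1CCOCC1)c1ccccn1`, in a functional assay on A-431 cells (Homo sapiens) for cytotoxicity, read by MTT assay, with a stated time of 72 h, tested at 1 uM; a lower number here means less inhibition of growth, a higher number more inhibition of growth at the concentration tested: 29.2%
Compound 2, `Cc1ccnc(/C(N)=N/NC(=S)N2CCOCC2)c1`, in this assay: 33.6%

Of the compounds shown here, two have been measured so far. Among the measured compounds shown here, compound 2 carries the numerically higher of the two numbers, but its only neighbour is compound 1, and the step of a number 4.4 percentage points higher from compound 1 to compound 2 (within the scatter) lies within the scatter, so the two are not told apart by this assay. That step consists of methyl in place of hydrogen on an aromatic carbon and leaves the thiocarbonyl end of the shared core untouched.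

Compound 3, `Cc1ccnc(/C(N)=N/NC(=S)N2CCSCC2)c1`, differs from compound 2 by thiomorpholin-4-yl in place of morpholin-4-yl on a thiocarbonyl carbon. For the measured compounds named here, none of the measured steps changes this part of the molecule, so there is no measured precedent for the size or direction of its effect; the only known step, a number 4.4 percentage points higher from compound 1 to compound 2 (within the scatter), concerns a different site and was itself within the scatter. On that basis no step beyond the scatter is expected in this assay for compound 3, and the expected step of a number 0.6 percentage points lower from compound 2 to compound 3 (within the scatter) is essentially flat. Compound 3 is therefore estimated at 33%, with a range of 18% to 48%.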

Compound 3, percent growth inhibition at one concentration: 34.6%
Compound 3: the middle estimate sits 1.6 percentage points below what was measured; the measured number falls inside the stated range.
By their numbers in this assay, from the lowest: compounds 1, 2 and 3 (each within the scatter of the next).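

With this step the thiocarbonyl carbon, which the earlier step from compound 1 to compound 2 left untouched, now has a measured change: thiomorpholin-4-yl in place of morpholin-4-yl gives a number 1 percentage points higher from compound 2 to compound 3 (within the scatter) in this assay. The two groups match in heavy-atom count, ring size and counted hydrogen-bond donors and acceptors, and differ in that sulfur stands where oxygen stood, so compound 2 and compound 3 are not told apart by this assay at this one concentration. Taken with the first step, this means that neither of the two single changes shown, one on an aromatic carbon and one on the thiocarbonyl carbon, gives a difference beyond the scatter, and no other measurement bears on why this is so.

What the compounds shown leave open is whether a group of another kind on the thiocarbonyl carbon, such as dimethylamino, piperidin-1-yl or 4-methylpiperazin-1-yl, would stand apart from compound 3 in this assay. Also open, from the compounds shown here alone, is whether the ring sulfur and the aromatic methyl have any joint effect, which would need the thiomorpholin-4-yl group on the core of compound 1.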